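Replacing the aminophenyl on the carbonyl carbon

The source may report more compounds than this note shows. Statements on the series, on what has been measured and on what is new or still open speak of the compounds shown alone.

Compound 1 `COc1cc(-c2cc(/C=C/C(=O)c3ccc(N)cc3)[nH]n2)cc(OC)c1OC` and compound 2 `COc1cc(-c2cc(/C=C/C(=O)c3ccc(Cl)c(Cl)c3)[nH]n2)cc(OC)c1OC` share one core and differ only in the ring attached to the carbonyl carbon. In a functional assay on SF-268 cells (Homo sapiens) for cytotoxicity, read by sulforhodamine B assay, with a stated time of 48 h, tested at 10 uM (on this read-out lower numbers stand for a stronger effect and higher numbers for a weaker effect at the one concentration tested), compound 1 gives -55%, the lowest of the two numbers recorded so far, and in this assay compound 2 gives 60%. Among the measured compounds shown here, the single measured step, a number 115 percentage points higher from compound 1 to compound 2 (beyond the scatter), shows that exchanging the aminophenyl on the carbonyl carbon for a ring lacking the amino group weakens the effect markedly.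

Compound 3 `COc1ccc(C(=O)/C=C/c2cc(-c3cc(OC)c(OC)c(OC)c3)n[nH]2)cc1OC` has not yet been measured. It differs from compound 1 in one place: 3,4-dimethoxyphenyl in place of 4-aminophenyl on a carbonyl carbon. For the measured compounds named here, as in the step to compound 2, the aminophenyl is taken away and a different ring is put on the same carbonyl carbon, so the one step that bears on this change is a number 115 percentage points higher from compound 1 to compound 2 (beyond the scatter), a large rise. Going by the values given here, a rise is therefore expected here as well, though a dimethoxyphenyl is not a dichlorophenyl and only one step is available to judge its size. Compound 3 is expected to give 30%, within -20% to 75%, which corresponds to an estimated step of a number 85 percentage points higher from compound 1 to compound 3 (beyond the scatter).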

Compound 3, a percentage reported as activity, at one concentration (the size of the read-out at that concentration, not a potency): -60%
The estimate for compound 3 lay 90 percentage points above the measured number, outside the stated range (below it).
By their numbers in this assay, from the lowest: compounds 3 and 1 (each within the scatter of the next); then compound 2.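

In this assay, exchanging the aminophenyl gives a number 5 percentage points lower from compound 1 to compound 3 (within the scatter) and so shows that removing the 4-aminophenyl from the carbonyl carbon does not by itself weaken the effect: a ring with no amino group and no hydrogen-bond donor can take its place without a change beyond the scatter. The comparison with the dichlorinated ring gives a number 120 percentage points lower from compound 2 to compound 3 (beyond the scatter) and shows that the large loss seen earlier goes with the 3,4-dichlorophenyl specifically, not with every replacement of the aminophenyl, so compound 2 stands apart from the other two compounds at this position. No measurement here accounts for the difference between the methoxy and chloro groups on this ring.

The compounds shown leave open how a phenyl ring with a single chlorine, a single methoxy group, or no group at all would behave on this carbonyl carbon. Among the compounds shown here, with only three rings compared at one concentration, it also remains open whether a hydroxyl group or a carboxylic acid on the ring would keep the effect of compound 1 and compound 3 or lose it as in compound 2.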